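Replacing Methyl with Trifluoromethoxy on the Aromatic Carbon

The compounds below may be only part of what the source reports. "The series", "measured", "known", "first", "only" and "open" are said of these compounds alone.

Measured in a functional assay on cells (Neuron, Rattus norvegicus) for inhibition, read by LDH release, with a stated time of 24 h; a lower number here means a stronger inhibitor, a higher number a weaker inhibitor
compound 1 `CN(c1ccc(Br)cc1)c1nc(=O)c2cccnc2s1` gives 1000 nM
compound 2 `COc1ccc(N(C)c2nc(=O)c3cccnc3s2)cc1` gives 3400 nM
compound 3 `Cc1ccc(N(C)c2nc(=O)c3cccnc3s2)cc1` gives 10000 nM

Compound 3 has the highest number of the three, which makes it the weakest inhibitor in the set in this assay and the natural starting point for this step. The next compound, compound 4 `CN(c1ccc(OC(F)(F)F)cc1)c1nc(=O)c2cccnc2s1` and still unmeasured, carries trifluoromethoxy in place of methyl on an aromatic carbon and keeps the shared core.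

Within the data shown here, no measured compound carries trifluoromethoxy, so only the neighbouring changes at this same place can guide the expectation. Methyl in place of methoxy gave a 2.9-fold higher number from compound 2 to compound 3 (0.47 log units; beyond the scatter) and methyl in place of bromo gave a 10-fold higher number from compound 1 to compound 3 (1.00 log units; beyond the scatter) in these data. Methoxy in place of bromo gave a 3.4-fold higher number from compound 1 to compound 2 (0.53 log units; beyond the scatter) as well. Both measured replacements involving the methyl of compound 3 show it with the higher number, so a modest step to a lower number is expected here, though three compounds are thin support. For compound 4 the estimated change is a 5.0-fold lower number from compound 3 to compound 4 (0.70 log units; beyond the scatter) in the direction of stronger inhibition. Compound 4 is expected at 2000 nM with an estimated range from 500 nM to 8000 nM in this test.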

Compound 4, half-maximal inhibitory concentration: 2100 nM
Compound 4: middle estimate off by 1.1-fold (0.02 log units), on the low side, within the range that was stated.
By their numbers in this assay, from the lowest: compound 1; then compounds 4 and 2 (each within the scatter of the next); then compound 3.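

In this assay, trifluoromethoxy in place of methyl gives a 4.8-fold lower number from compound 3 to compound 4 (0.68 log units; beyond the scatter), the third replacement of this methyl to give a lower number, so compound 3 remains the weakest inhibitor of the four whether it is set against bromo, methoxy or trifluoromethoxy. Trifluoromethyl in place of the methyl on the oxygen gives a 1.6-fold lower number from compound 2 to compound 4 (0.21 log units; within the scatter), so this change does not separate the two compounds, while trifluoromethoxy in place of bromo gives a 2.1-fold higher number from compound 1 to compound 4 (0.32 log units; beyond the scatter) and leaves compound 1 the strongest inhibitor of the four. Nothing beyond these numbers is at hand to explain the order of the groups at this aromatic carbon.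

The compounds shown leave open how a nitrile, an amine or a carboxylic acid on this aromatic carbon would compare with bromo, and whether any group here could give a lower number than compound 1 does. All four compounds keep the shared core and differ at this one place, so they also leave open whether the same order of groups would hold if the methyl on the nitrogen gave way to a longer chain.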